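Fluoro added to the aryl sulfonamide core of compound 1

The source may report more compounds than this note shows. Statements on the series, on what has been measured and on what is new or still open speak of the compounds shown alone.

Compound 1 `C[C@H](Nc1ccc(S(=O)(=O)Nc2nccs2)cc1Cl)c1ccccc1` gives 130 nM in an assay on HEK293 cells for inhibition of SCN8A/SCN1B (Homo sapiens), read by patch clamp, with a stated time of 20 min (a higher number here means a weaker inhibitor, a lower number a stronger inhibitor), the lowest of the two numbers shown. Going by the values given here, its only neighbour is compound 2 `C[C@@H](Nc1ccc(S(=O)(=O)Nc2nccs2)cc1Cl)c1ccccc1`, which in this assay gives 620 nM; the step is a 4.8-fold higher number from compound 1 to compound 2 (0.68 log units; beyond the scatter), and the two compounds differ solely in the drawn configuration at the saturated chain carbon, as seen from the fact that compounds 1 and 2 differ only in the configuration as drawn.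

Compound 3 `C[C@H](Nc1cc(F)c(S(=O)(=O)Nc2nccs2)cc1Cl)c1ccccc1` keeps the configuration of compound 1 and adds (fluoro in place of hydrogen on an aromatic carbon), that is, fluoro in place of hydrogen on an aromatic carbon, para to the chloro group, ortho to one group of 9 heavy atoms and meta to the other.

Among the compounds with values here, no measured step bears on this change: the single step, a 4.8-fold higher number from compound 1 to compound 2 (0.68 log units; beyond the scatter), concerns the stereocentre, not a substituent on the aromatic ring. With nothing to point either way, the expectation for compound 3 is a step of no change at the digits printed from compound 1 to compound 3 (within the scatter), that is, no change beyond the scatter. The estimate for compound 3 in this assay is 130 nM, with a range from 50 nM to 350 nM.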

Compound 3, half-maximal inhibitory concentration: 20 nM
Compound 3: the middle estimate sits 6.5-fold (0.81 log units) above what was measured; the whole stated range lies above it.
By their numbers in this assay, from the lowest: compound 3; then compound 1; then compound 2.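

In this assay, the change shows a 6.5-fold lower number from compound 1 to compound 3 (0.81 log units; beyond the scatter), so this aromatic carbon, para to a chloro group, is a place on the core of compound 1 where replacing one hydrogen with fluoro makes a stronger inhibitor by a margin beyond the scatter. Going by these compounds alone, until now the series held only one step, a 4.8-fold higher number from compound 1 to compound 2 (0.68 log units; beyond the scatter), which concerned the stereocentre at the saturated chain carbon and gave no reading on the aromatic ring; the ring now proves responsive to an entering group of 1 heavy atom, with no ring, no hydrogen-bond donors or acceptors and no net charge. Nothing at hand explains why fluoro has this effect here.

Open, going by these compounds, is whether the difference in drawn configuration seen with compound 1 and compound 2 carries over once fluoro is on the ring. Also open, on these data alone, is whether the lower number belongs to fluoro specifically or would also come with a methyl, a methoxy or a nitrile on the same aromatic carbon, and whether fluoro on the other aromatic carbons would give a similar step.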